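This account rests on a few compounds, and the source may have more. Where it says the series, first, only, none or still open, it means among the compounds named here.

Measured so far:
compound 1 `CCc1ccccc1N(Cc1nnc(Cc2ccccc2)o1)S(=O)(=O)c1ccc(C)cc1`, 398 nM
compound 2 `COc1ccc(Cc2nnc(CN(c3cccc(C(F)(F)F)c3C)S(=O)(=O)c3ccc(C)cc3)o2)cc1`, 398 nM
compound 3 `Cc1ccc(S(=O)(=O)N(Cc2nnc(Cc3ccc(N(C)C)cc3)o2)c2cccc(Cl)c2C)cc1`, 20 nM

All three values come from a functional assay on CHO cells for antagonist activity at prostaglandin E2 receptor EP1 subtype (Homo sapiens), read by FLIPR and calcium flux; on this read-out higher numbers stand for weaker inhibition and lower numbers for stronger inhibition. Compound 3 holds the lowest number of the three. Compound 1 and compound 2 sit at the same number, each well beyond the scatter away from compound 3, so compound 3 is the strongest inhibitor of the set as measured. Going by the values given here, no two measured compounds differ in only one place, so no single change has yet been tied to a size of step; compounds 1 and 2 differ from compound 3 both in the benzyl part and in the sulfonamide aniline, and only their two values can be compared.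

The next compound to go into this assay is compound 4 `Cc1ccc(S(=O)(=O)N(Cc2nnc(Cc3cccc(Cl)c3)o2)c2cccc(Cl)c2C)cc1`. Against compound 3 the change is 3-chlorophenyl in place of 4-(dimethylamino)phenyl on a saturated chain carbon bound to an aromatic carbon. The aniline part of compound 3 is kept. The two compounds with a benzyl group lacking the dimethylamino, compound 1 and compound 2, both read higher than compound 3, though each carries a different aniline, so this is a hint and not a measured step. A moderate weakening is expected for compound 4, of the size a 3.0-fold higher number from compound 3 to compound 4 (0.48 log units; beyond the scatter). In this assay compound 4 is estimated at 60 nM, within 15 nM to 250 nM.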

Compound 4, inhibition constant: 2000 nM
Beside the measured number, compound 4's estimate is 33-fold (1.52 log units) below it; the whole stated range lies below it.
By their numbers in this assay, from the lowest: compound 3; then compounds 1 and 2 (each within the scatter of the next); then compound 4.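

In this assay, going by these compounds alone, 3-chlorophenyl in place of 4-(dimethylamino)phenyl on a saturated chain carbon bound to an aromatic carbon gives a 100-fold higher number from compound 3 to compound 4 (2.00 log units; beyond the scatter), the first single change with a measured size, and a large one. Within the data shown here, with the aniline part held constant, this position alone can therefore move the number far beyond the scatter, something the earlier compounds could not show as none of them differed in only one place. No measured property of either group is available to account for the size of this step.

As far as these compounds go, the change swaps the substituent and also moves it on the phenyl, as the two group names show, so this single step cannot separate the loss of the dimethylamino group from the change of place, and it remains unknown whether the step would be of similar size with a different aniline part. Also open, from the compounds shown here alone, is how an amino group, a morpholine or a carboxylic acid would read in place of the dimethylamino group.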